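The source may hold more compounds than are shown below. What is called first, only, known or untested is meant among the compounds shown, and "the series" means these compounds.

In a functional assay on cells (KATO III cell, Homo sapiens) for antiproliferative activity, read by MTT assay (a higher number here means a weaker inhibitor, a lower number a stronger inhibitor), compound 1 `O=C1NC(c2ccccc2)CN1S(=O)(=O)c1ccc2c(c1)CCCN2` gives > 20000 nM, which is a limit of the assay. Compound 2 `CCCOC(=O)N1CCCc2cc(S(=O)(=O)N3CC(c4ccccc4)NC3=O)ccc21` gives 3300 nM, and compound 3 `C=CCOC(=O)N1CCCc2cc(S(=O)(=O)N3CC(c4ccccc4)NC3=O)ccc21` gives 5050 nM. These two values lie within the scatter of each other, with a 1.5-fold higher number from compound 2 to compound 3 (0.18 log units; within the scatter). Adding propoxycarbonyl or allyloxycarbonyl in place of hydrogen gave an at least 6.0-fold lower number from compound 1 to compound 2 (0.78 log units; beyond the scatter) and an at least 3.9-fold lower number from compound 1 to compound 3 (0.59 log units; beyond the scatter). Compound 4 `O=C(CCl)N1CCCc2cc(S(=O)(=O)N3CC(c4ccccc4)NC3=O)ccc21` carries chloromethyl in place of allyloxy on a carbonyl carbon. Going by the values given here, the only measured change within the group on that carbonyl, a 1.5-fold higher number from compound 2 to compound 3 (0.18 log units; within the scatter), stayed within the scatter, so no step beyond the scatter is expected in this assay, although no measured step covers this replacement. The expected step is a 1.7-fold lower number from compound 3 to compound 4 (0.23 log units; within the scatter). For compound 4 the estimate is 3000 nM, with an expected range of 500 nM to 15000 nM.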

Compound 4, half-maximal inhibitory concentration: 3460 nM
The estimate for compound 4 lay 1.2-fold (0.06 log units) below the measured number; measured number inside the range.
By their numbers in this assay, from the lowest: compounds 2, 4 and 3 (each within the scatter of the next). At a limit, above all of these: compound 1.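

In this assay, the carbonyl group on the ring nitrogen need not carry an oxygen-linked chain: chloromethyl in place of allyloxy gives a 1.5-fold lower number from compound 3 to compound 4 (0.16 log units; within the scatter), and chloromethyl in place of propoxy gives a 1.0-fold higher number from compound 2 to compound 4 (0.02 log units; within the scatter). The three groups on that carbonyl therefore remain undistinguished here. (Chloromethyl)carbonyl in place of hydrogen also gives an at least 5.7-fold lower number from compound 1 to compound 4 (0.76 log units; beyond the scatter), a step bounded by a limit rather than fully sized: the limit of > 20000 nM in this assay, at which 1 of the 4 values shown sits.

On these data alone, whether the chlorine itself contributes remains open. Also open, as far as these compounds go, is whether an amine, a carboxylic acid or a longer chain on this carbonyl would give a step beyond the scatter.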